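The source may report more compounds than this note shows. Statements on the series, on what has been measured and on what is new or still open speak of the compounds shown alone.

Compound 1 `CCCCCCCC(CCO)n1cnc2c(OC)ncnc21`: 23900 nM
Compound 2 `CCCCCCCC(CCO)n1cnc2c(N)ncnc21`: > 50000 nM (a limit)
Compound 3 `CCCCCCCC(CCO)n1cnc2c(N)nc(Cl)nc21`: > 50000 nM (a limit)

All three were tested in a functional assay on SW480 cells (Homo sapiens) for antiproliferative activity, read by MTT assay, with a stated time of 48 h; on this read-out higher numbers stand for weaker inhibition and lower numbers for stronger inhibition. Compound 2 stands at > 50000 nM, which is a limit of the assay and not a number. It shares this position with compound 3, as the limit of > 50000 nM in this assay, at which 2 of the 3 values shown sit, shows.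

Compound 4 `CCCCCCCCCCC(CCO)n1cnc2c(N)ncnc21` differs from compound 2 by propyl in place of hydrogen on a saturated chain carbon, eight bonds along the chain from an aromatic nitrogen. Both measured steps change an aromatic carbon, not the chain, so they offer only indirect guidance. One is an at least 2.0-fold higher number from compound 1 to compound 2 (0.32 log units; beyond the scatter), which is beyond the scatter. The other is a step that the two limits leave unreadable from compound 2 to compound 3, which cannot be sized.

The expected change is small, towards stronger inhibition, and is estimated as an at least 1.2-fold lower number from compound 2 to compound 4 (0.09 log units; that floor lies within the scatter). Another limit may well be reported. For compound 4 the estimate is 40000 nM, with an expected range of 15000 nM to 50000 nM.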

Compound 4, half-maximal inhibitory concentration: 1200 nM
Beside the measured number, compound 4's estimate is 33-fold (1.52 log units) above it; measured number below the stated range.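

Propyl in place of hydrogen on a saturated chain carbon, eight bonds along the chain from an aromatic nitrogen, gives an at least 41-fold lower number from compound 2 to compound 4 (1.61 log units; beyond the scatter) in this assay. Among these compounds, the earlier steps changed only an aromatic carbon, so this is the first sign that the length of the chain can move the read-out strongly. Compound 2 holds a limit and not a number, so this step gives only a floor for the size of the change: the limit of > 50000 nM in this assay, at which 2 of the 4 values shown sit. From the compounds shown here alone, whether a longer chain would lower the number further stays open, and so does the effect of an amine in place of propyl.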